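Toward Compound 4: a Chloro for a Propoxy Group

The source may hold more compounds than are shown below. What is called first, only, known or untested is meant among the compounds shown, and "the series" means these compounds.

Compound 1 `CC(C)Cc1ccc(C(=O)/C=C/c2ccc(C(=O)O)cc2)cc1` was tested in an ADME assay on Vero cells (Chlorocebus sabaeus) for cytotoxicity, read by MTT assay, with a stated time of 72 h; on this read-out higher numbers stand for lower toxicity in this test and lower numbers for higher toxicity in this test. In this assay compound 1 gives only a limit, < 10 ug/mL, not a number. Compound 3 `CCCOc1ccc(C(=O)/C=C/c2ccc(C(=O)O)cc2)cc1` likewise gives only a limit of < 10 ug/mL in this assay. Compound 2 `CCOc1ccc(C(=O)/C=C/c2ccc(C(=O)Nc3cccc(-c4cc(C(=O)OC)no4)c3)cc2)cc1` in this assay also gives a limit, > 40 ug/mL. The step that the two limits leave unreadable from compound 1 to compound 3 is thus unreadable; compound 3 stands at the limit of < 10 ug/mL in this assay, at which 2 of the 3 values shown sit, together with compound 1, while compound 2 sits at the limit of > 40 ug/mL in this assay, at which 1 of the 3 values shown sits. Compound 4 `O=C(O)c1ccc(/C=C/C(=O)c2ccc(Cl)cc2)cc1` differs from compound 3 in one place: chloro in place of propoxy on an aromatic carbon. For the measured compounds named here, the one measured step concerns a swap at this aromatic carbon and its size is hidden by the limits, so no step beyond the scatter is expected. Compound 4 is expected to give 8 ug/mL, in a range from 3 ug/mL to 20 ug/mL, which means an expected step that the limit leaves unreadable from compound 3 to compound 4.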

Compound 4, half-maximal cytotoxic concentration: < 10 ug/mL
Compound 4: only a limit was reported (the forecaster's own chance of this, stated with the estimate: 70%); the middle value is on the limit's open side.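

For the compounds shown here, compound 1, compound 3 and compound 4 each give only a limit, and no step among them can be read. The compounds shown leave open how the isobutyl, propoxy and chloro groups compare on this read-out.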